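Shifting the Methyl on the Anilide of Compound 1

This account rests on a few compounds, and the source may have more. Where it says the series, first, only, none or still open, it means among the compounds named here.

Compound 1 `COc1ccc2c(=O)c(/C=C/C(=O)Nc3ccc(C)cc3)coc2c1`: in a functional assay (QGY7701 cells, Homo sapiens) for inhibition, read by MTT assay, with a stated time of 48 h (a higher number here means a weaker inhibitor, a lower number a stronger inhibitor), compound 1 gives 39300 nM.
Compound 2 `COc1ccc2c(=O)c(/C=C/C(=O)NCc3ccc(F)cc3)coc2c1`: in this assay compound 2 gives 7960 nM.

Among the compounds with values here, compound 1 stands at the highest of the two numbers measured so far; its nearest neighbour is compound 2, reached by a 4.9-fold lower number from compound 1 to compound 2 (0.69 log units; beyond the scatter), a change of 4-fluorobenzyl in place of 4-methylphenyl on an amide-type nitrogen. Compound 3 `COc1ccc2c(=O)c(/C=C/C(=O)Nc3cccc(C)c3)coc2c1` keeps the shared core of compound 1 and differs from it in a single place: 3-methylphenyl in place of 4-methylphenyl on an amide-type nitrogen. Within the data shown here, the only measured step alters both the group on the amide-type nitrogen and the ring substituent at once, so it bears only loosely on the change to compound 3, which keeps the same atoms joined differently. Among the measured compounds shown here, no measured pair isolates the position of the methyl on the ring. A step of modest size is therefore plausible, but none beyond the scatter is expected, in either direction. Compound 3 is expected to give an estimated 30000 nM in this assay, with a range of 10000 nM to 90000 nM. That estimate means an expected step of a 1.3-fold lower number from compound 1 to compound 3 (0.12 log units; within the scatter).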

Compound 3, half-maximal inhibitory concentration: > 100000 nM
Compound 3: no number, only a limit; the forecaster's own chance of this, stated with the estimate: 20%; middle value at least 3.3-fold (0.52 log units) away from the limit.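

Exchanging 4-methylphenyl for 3-methylphenyl on the amide-type nitrogen adds and removes no atom, yet in this assay it gives an at least 2.5-fold higher number from compound 1 to compound 3 (0.40 log units; beyond the scatter), so the place of the methyl on this ring matters by itself, something the earlier pair, which altered the nitrogen group and the ring substituent together, could not isolate. For compound 3 the reading is a limit of the assay and not a number, so this step and the next have only a lower bound on their size: the limit of > 100000 nM in this assay, at which 1 of the 3 values shown sits.

The change from 4-fluorobenzyl to 3-methylphenyl on the same nitrogen gives an at least 12-fold higher number from compound 2 to compound 3 (1.09 log units; beyond the scatter), a large step that sets the 4-fluorobenzyl amide well apart from the 3-methylphenyl amide in this cell assay.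

As far as these compounds go, what a plain phenyl, a methoxyphenyl or an unsubstituted benzyl on this nitrogen would give remains open, and with it whether the methyl in the 3-methylphenyl group is itself the cause of the loss or whether any group there would do the same. The compounds shown also do not separate the contribution of the extra carbon in the benzyl group from that of the fluorine.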